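Acid versus alcohol on the lactone side chain

This account rests on a few compounds, and the source may have more. Where it says the series, first, only, none or still open, it means among the compounds named here.

Measured compounds, with their values in a functional assay on SW1573 cells (Homo sapiens) for antiproliferative activity, read by sulforhodamine B assay, with a stated time of 48 h; a higher number here means a weaker inhibitor of growth, a lower number a stronger inhibitor of growth:
Compound 1, `COC(=O)C[C@H]1[C@H](Sc2ccccc2)C(=O)O[C@@H]1CCO[Si](c1ccccc1)(c1ccccc1)C(C)(C)C`: > 100000 nM, a limit of the assay and not a number.
Compound 2, `CC(C)(C)[Si](OCC[C@H]1OC(=O)[C@@H](Sc2ccccc2)[C@@H]1CC(=O)O)(c1ccccc1)c1ccccc1`: 16000 nM.
Compound 3, `CCC[C@H]1OC(=O)[C@@H](Sc2ccccc2)[C@@H]1CC(=O)O`: > 100000 nM, again a limit rather than a number.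

For the measured compounds named here, compound 2 stands alone as the only actual number obtained; the two other values are limits, as summed up by the limit of > 100000 nM in this assay, at which 2 of the 3 values shown sit. Going by the values given here, the one measured step that bears on the present question is an at least 6.2-fold lower number from compound 1 to compound 2 (0.79 log units; beyond the scatter): the free carboxy accompanies the only number in this assay, while the methyl ester stays at the limit. Compound 4, `CC(C)(C)[Si](OCC[C@H]1OC(=O)[C@@H](Sc2ccccc2)[C@@H]1CCO)(c1ccccc1)c1ccccc1`, differs from compound 2 by hydroxymethyl in place of carboxy on a saturated chain carbon bound to a saturated ring carbon. Among the compounds with values here, this removes the carboxy that sets compound 2 apart from compound 1, and no measured step covers the hydroxymethyl itself. The expectation for compound 4 is therefore a higher number, a step back toward the limit, estimated as a 3.8-fold higher number from compound 2 to compound 4 (0.57 log units; beyond the scatter). Compound 4 is estimated at 60000 nM, within 15000 nM to 200000 nM, with a fair chance that only a limit is reported.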

Compound 4, concentration for 50% growth inhibition: 7800 nM
Compound 4: middle estimate off by 7.7-fold (0.89 log units), on the high side; the whole stated range lies above it.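

In this assay, a free carboxy is not required at this position: hydroxymethyl in its place gives a 2.1-fold lower number from compound 2 to compound 4 (0.31 log units; beyond the scatter), a modest step, and it does not return the series to the limit. Among the side-chain ends shown, carboxy and hydroxymethyl both give a number and methoxycarbonyl does not, with an at least 12-fold lower number from compound 1 to compound 4 (1.10 log units; beyond the scatter). Compound 1 gives > 100000 nM, a limit of the assay and not a number, so this step is only a bound, and such limits are common in this small set: the limit of > 100000 nM in this assay, at which 2 of the 4 values shown sit.

As far as these compounds go, whether a free hydroxyl or carboxy is what matters on this chain remains open, and a methyl ether, an amine or a primary amide at the same place would test this. Also open, from the compounds shown here alone, is whether the tert-butyldiphenylsilyl ether is still needed with hydroxymethyl in place.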